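The source may hold more compounds than are shown below. What is called first, only, known or untested is meant among the compounds shown, and "the series" means these compounds.

Compound 1 `O=C(C(Nc1ccccc1F)c1ccc(C(F)(F)F)cc1)N1CCCC1c1cccnc1` gives 7 nM in an assay on HEK293 cells for antagonist activity at transient receptor potential M8 protein (Canis lupus familiaris), read by fluorescence and calcium flux, with a stated time of 5 min; a lower number here means a stronger inhibitor, a higher number a weaker inhibitor.
Compound 2 `O=C(O)c1cccc(C2CCCN2C(=O)C(Nc2ccccc2F)c2ccc(C(F)(F)F)cc2)c1` gives 40 nM in this assay.

Within the data shown here, compound 2 holds the highest of the two numbers measured so far; its nearest neighbour is compound 1, and the gap is a 5.7-fold higher number from compound 1 to compound 2 (0.76 log units; beyond the scatter). Compound 3 `O=C(O)c1cccc([C@@H]2CCCN2C(=O)C(Nc2ccccc2F)c2ccc(C(F)(F)F)cc2)c1` differs from compound 2 only in how the stereochemistry is drawn: the two compounds have the same atoms and bonds; at least one stereo element is drawn with a configuration in one of them and without one in the other: 1 of 2 stereo elements differ; a stereocentre at a saturated ring carbon is drawn without a configuration in compound 2 and S in compound 3. Among the measured compounds shown here, no measured step bears directly on such a change: the single recorded step, a 5.7-fold higher number from compound 1 to compound 2 (0.76 log units; beyond the scatter), swaps one group for another and says nothing about separating a single configuration from a mixture. Compound 2 covers both configurations, so its value reflects a blend; compound 3 is one of the two and may give a somewhat lower number if it carries the activity, or a clearly higher one if it does not. As an expectation, compound 3 is estimated at 25 nM, within 8 nM to 300 nM, which corresponds to the expected step of a 1.6-fold lower number from compound 2 to compound 3 (0.20 log units; within the scatter).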

Compound 3, half-maximal inhibitory concentration: 33 nM
Compound 3: the middle estimate sits 1.3-fold (0.12 log units) below what was measured; measured number inside the range.
By their numbers in this assay, from the lowest: compound 1; then compounds 3 and 2 (each within the scatter of the next).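

The step in this assay is a 1.2-fold lower number from compound 2 to compound 3 (0.08 log units; within the scatter), so compound 3, drawn as S at the saturated ring carbon, cannot be told apart from compound 2, which is drawn without a configuration there. The S form therefore keeps activity in the same range as compound 2 and is not an inactive partner at this carbon. The comparison isolates a single structural point, since nothing else distinguishes the two drawings: the fact that one of compounds 2 and 3 is drawn with a defined configuration and the other without, at the place where they differ

On these data alone, the value of the R form at this ring carbon remains open, as does the effect of the other stereo element, which is drawn without a configuration in both compounds. Also open, as far as these compounds go, is whether a primary amide or a nitrile in place of the carboxylic acid would give a number close to that of compound 3.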